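Series notes: three limit readings and a trimmed substituent

The source may report more compounds than this note shows. Statements on the series, on what has been measured and on what is new or still open speak of the compounds shown alone.

Compound 1 `COCc1nc(C)c2c(C)nnc(O)n12`, compound 2 `CCOC(=O)Cn1ncc2cncn2c1=O` and compound 3 `CCCc1nc(C)c2cnn(CC3CC3)c(=O)n12` have each been run in a functional assay for inhibition, with Homo sapiens as the target; a higher number here means a weaker inhibitor, a lower number a stronger inhibitor. In this assay compound 1 gives > 48000 nM, which is a limit of the assay and not a number. In this assay compound 2 gives > 48000 nM, again a limit. In this assay compound 3 gives > 48000 nM, also a limit. Compound 3 therefore stands only at the bound of the assay, as do the others: the limit of > 48000 nM in this assay, at which 3 of the 3 values shown sit. Going by the values given here, no order among compound 1, compound 2 and compound 3 can be drawn from this, and no measured step exists in the set.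

Compound 4 `CCCc1nc(C)c2cnn(C)c(=O)n12` has not yet been measured. It differs from compound 3 by hydrogen in place of cyclopropyl on a saturated chain carbon bound to an aromatic nitrogen; cut one bond further out, the change reads cyclopropylmethyl to methyl. With compound 3 at the limit, the step from compound 3 to compound 4 is expected to be a step that the limit leaves unreadable from compound 3 to compound 4, that is, nothing beyond the scatter. Compound 4 is estimated at 60000 nM, within 20000 nM to 200000 nM, and will most likely again be reported only as a limit.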

Compound 4, half-maximal inhibitory concentration: 20000 nM
Compound 4: the middle estimate sits 3.0-fold (0.48 log units) above what was measured; the measured number falls inside the stated range.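

In this assay, going by these compounds alone, the change from cyclopropylmethyl to methyl gives an at least 2.4-fold lower number from compound 3 to compound 4 (0.38 log units; beyond the scatter) and is the first change that reads beyond the scatter. Compound 4 is also the only compound shown that carries a number and not a limit, so the series now has one measured point to work from. The full size of the step cannot be read because compound 3 rests on a limit of the assay: the limit of > 48000 nM in this assay, at which 3 of the 4 values shown sit.

From the compounds shown here alone, it remains open whether the step follows the loss of the three-membered ring or the shortening of the group, and an ethyl group or a longer open chain in place of the methyl would separate these two readings. Going by these compounds, how an amine or a carboxylic acid at the end of such a chain would read is also open.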